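The source may report more compounds than this note shows. Statements on the series, on what has been measured and on what is new or still open speak of the compounds shown alone.

Compound 2 `Clc1ccc(COc2ccc(/C=C/C(/C=C/c3ccccn3)=N/Oc3ncnc4cc(Cl)ccc34)cc2)c(Cl)c1` stands lowest of the two numbers in hand: in a functional assay on SMMC-7721 cells (Homo sapiens) for inhibition, read by MTT assay, with a stated time of 72 h, tested at 10 uM (a lower number here means a weaker effect, a higher number a stronger effect of the compound at the concentration tested), compound 2 gives 23.6%. Its nearest neighbour is compound 1 `Clc1ccc2c(O/N=C(/C=C/c3ccc(OCc4ccccc4Cl)cc3)\C=C\c3ccccn3)ncnc2c1`, which in this assay gives 84.7%. Going by the values given here, the one measured step, a number 61.1 percentage points lower from compound 1 to compound 2 (beyond the scatter), comes from a single alteration, chloro in place of hydrogen on an aromatic carbon, and it is large.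

Compound 3 `Fc1ccccc1COc1ccc(/C=C/C(/C=C/c2ccccn2)=N/Oc2ncnc3cc(Cl)ccc23)cc1` is not yet measured. It differs from compound 2 as follows: 2-fluorophenyl in place of 2,4-dichlorophenyl on a saturated chain carbon bound to an oxygen on an aromatic ring. Among the compounds with values here, this change removes the chloro that the step from compound 1 to compound 2 added, and at the same time exchanges the remaining chloro for fluoro; no measured pair covers that second exchange. Within the data shown here, the only step that bears on the move is a number 61.1 percentage points lower from compound 1 to compound 2 (beyond the scatter), and since compound 3 undoes the addition of that chloro, the expectation in this assay is an upward step, with the fluoro exchange leaving the size uncertain. For compound 3 the step expected in this assay is a number 38.4 percentage points higher from compound 2 to compound 3 (beyond the scatter). The estimated value for compound 3 in this assay is therefore 62%, with a range from 28% to 90%.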

Compound 3, a percentage reported as inhibition, at one concentration (the size of the read-out at that concentration, not a potency): 91.2%
Beside the measured number, compound 3's estimate is 29.2 percentage points below it, outside the stated range (above it).
By their numbers in this assay, from the lowest: compound 2; then compounds 1 and 3 (each within the scatter of the next).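

Set against the earlier pair, compound 3 separates the two halogen changes: a number 6.5 percentage points higher from compound 1 to compound 3 (within the scatter) in this assay shows that fluoro in place of chloro on an aromatic carbon gives no readable change, so in this pair either halogen serves equally well on that ring. The a number 67.6 percentage points higher from compound 2 to compound 3 (beyond the scatter) then has nearly the size of a number 61.1 percentage points lower from compound 1 to compound 2 (beyond the scatter) in the opposite direction, and among these three compounds the low read-out belongs only to the one carrying 2,4-dichlorophenyl on a saturated chain carbon bound to an oxygen on an aromatic ring, while the two carrying a single halogen on that ring stay together within the scatter. Nothing available here accounts for why the second chloro carries such a large loss.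

The compounds shown leave open whether the loss is specific to chloro, since no difluorophenyl group or other pair of substituents on this ring appears among them. They also leave open whether an unsubstituted phenyl, or a methoxy or methyl group in place of the single halogen, would hold the read-out at the level of compound 1 and compound 3.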